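A few compounds are considered here, and "the series" means these few. Any claim that something is new, unique, unknown or untested is made for them only; others in the source may bear on it.

Compound 3 `O=C1C(c2ccccc2Cl)CC(c2ccccc2Cl)C(=O)N1Cc1ccccc1` is one of three related compounds tested in a functional assay on the whole organism (strain Swiss albino) for inhibition, with Mus musculus as the target, in the maximal electroshock model, with a stated time of 2 h, at a dose of 25 mg/kg by the intraperitoneal route; a higher number here means more inhibition at the dose given (going by the name of the read-out), a lower number less inhibition. Compound 1 `O=C1NC(=O)C(c2ccccc2Cl)CC1c1ccccc1Cl` gives 58.3%, compound 2 `CN1C(=O)C(c2ccccc2Cl)CC(c2ccccc2Cl)C1=O` gives 61.7%, and compound 3 gives 58.2%; compound 3 sits alongside both, since a number 0.1 percentage points lower from compound 1 to compound 3 (within the scatter) and a number 3.5 percentage points lower from compound 2 to compound 3 (within the scatter). Compound 4 `O=C1C(c2ccccc2Cl)CC(c2ccccc2Cl)C(=O)N1c1cccc(Cl)c1` differs from compound 3 by 3-chlorophenyl in place of benzyl on an amide-type nitrogen in a ring. Among the measured compounds shown here, the steps that bear on this change are the two leading to compound 3, a number 0.1 percentage points lower from compound 1 to compound 3 (within the scatter) and a number 3.5 percentage points lower from compound 2 to compound 3 (within the scatter), each showing that varying the group on the ring nitrogen left this assay unmoved. The author therefore expects no step beyond the scatter, a number 0.2 percentage points lower from compound 3 to compound 4 (within the scatter). Compound 4 is estimated at 58%, within a range from 45% to 72%.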

Compound 4, a percentage reported as inhibition, in the whole organism at one dose (the size of the read-out at that dose, not a potency): 43.7%
Beside the measured number, compound 4's estimate is 14.3 percentage points above it; measured number outside the range, below it.
By their numbers in this assay, from the lowest: compound 4; then compounds 3, 1 and 2 (each within the scatter of the next).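

In this assay, the group on the ring nitrogen proves not to be indifferent: 3-chlorophenyl gives a number 14.5 percentage points lower from compound 3 to compound 4 (beyond the scatter), a number 18 percentage points lower from compound 2 to compound 4 (beyond the scatter) and a number 14.6 percentage points lower from compound 1 to compound 4 (beyond the scatter), the first departure beyond the scatter in this small set. The change swaps benzyl for a ring that carries chlorine and stands directly on the nitrogen, so the drop belongs to that swap as a whole and not to either feature alone. No measurement offered here explains the drop. The compounds shown leave open whether plain phenyl on the nitrogen would give the same drop, which would separate the chlorine from the ring's direct attachment. They also leave open how a 3-chlorobenzyl group or a longer chain would behave there.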